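This account rests on a few compounds, and the source may have more. Where it says the series, first, only, none or still open, it means among the compounds named here.

Measured so far:
compound 1, `NC(=O)CC[C@H](NC(=O)CN(c1ncnc2c1ncn2C1CCCCO1)C1CC1)C(=O)OCc1ccccc1`: 22.3%
compound 2, `O=C(O)CNC(=O)CN(c1nc(Cl)nc2[nH]cnc12)C1CC1`: 19.8%

In a functional assay on the whole organism (Tail, strain ICR) with Mus musculus as the target, in the tail flick test, with a stated time of 120 min, at a dose of 25 umol/kg by the oral route (a lower number here means a weaker effect, a higher number a stronger effect of the compound at the dose given), compound 1 gives 22.3%, the higher of the two numbers recorded. Compound 2 gives 19.8% in this assay, and since the gap between the two lies within the scatter, no order between them can be read from these figures. The two also differ from each other in several places at once, so nothing about a single change can be learned from that pair.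

Compound 3, `N=C(N)NCCC[C@H](NC(=O)CN(c1ncnc2c1ncn2C1CCCCO1)C1CC1)C(=O)OCc1ccccc1`, has not been measured. It differs from compound 1 in one place: a group of 5 heavy atoms (2 carbon, 3 nitrogen; no ring) in place of a group of 3 heavy atoms (1 carbon, 1 nitrogen, 1 oxygen; no ring), on a saturated chain carbon, three bonds along the chain from an amide-type nitrogen and a carbonyl carbon. Within the data shown here, no measured pair shows what this exchange does in this assay, so there is no step to lean on. Among the measured compounds shown here, with only two values known, both close together and both modest, the step from compound 1 to compound 3 is expected to be small and of uncertain direction, most likely not beyond the scatter. The expected step is a number 2.7 percentage points higher from compound 1 to compound 3 (within the scatter). Compound 3 is therefore estimated at 25% in this assay, with a range from 10% to 45%.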

Compound 3, a percentage reported as activity, at one dose (the size of the read-out at that dose, not a potency): 38.2%
Compound 3: the middle estimate sits 13.2 percentage points below what was measured, and the stated range covers the measured number.
By their numbers in this assay, from the lowest: compounds 2 and 1 (each within the scatter of the next); then compound 3.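

Among these compounds, the exchange of the carbamoyl group for the group of 5 heavy atoms, on a saturated chain carbon, three bonds along the chain from an amide-type nitrogen and a carbonyl carbon, gives the only step that can be read for a single change in this assay, namely a number 15.9 percentage points higher from compound 1 to compound 3 (beyond the scatter). This position is therefore not indifferent in this test: with the rest of compound 1 kept, this one exchange moves the read-out by more than the scatter, which the earlier pair, differing in several places at once, could not show. Nothing available explains why the read-out rises with this exchange.

This single exchange cannot separate the effect of the size of the entering group from that of its nitrogen atoms, and an amine or a carboxylic acid on that same saturated chain carbon, or a longer chain carrying the carbamoyl group, would be needed to tell these apart. Going by these compounds, it also remains open whether the same exchange would give a similar step on another core, such as that of compound 2, or at any other dose or time.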